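Moving one chlorine: what to expect for compound 4

The source may hold more compounds than are shown below. What is called first, only, known or untested is meant among the compounds shown, and "the series" means these compounds.

Values in an ADME assay for permeability; on this read-out higher numbers stand for higher permeability and lower numbers for lower permeability
Compound 1 `CNC(=O)c1cc(C(=O)N[C@H]2CC[C@H](O)CC2)n([C@@H](C)c2cccc(Cl)c2)n1` gives 235 nm/s
Compound 2 `CNC(=O)c1cc(C(=O)N[C@H]2[C@@H]3C[C@H](O)C[C@@H]32)n([C@@H](C)c2cccc(Cl)c2)n1` gives 333 nm/s
Compound 3 `CCNC(=O)c1cc(C(=O)NC)nn1[C@@H](C)c1ccccc1` gives 435 nm/s
Compound 4 `CNC(=O)c1cc(C(=O)N[C@H]2CC[C@H](O)CC2)n([C@@H](C)c2ccccc2Cl)n1` is not yet measured

Compound 1 stands within the usual scatter of both compound 2 and compound 3, so these numbers show no real separation. Compound 4 has the same atoms as compound 1, joined differently: 2-chlorophenyl in place of 3-chlorophenyl on a saturated chain carbon bound to an aromatic nitrogen and a saturated chain carbon on a saturated chain carbon bound to an aromatic nitrogen and a saturated chain carbon. For the measured compounds named here, the only measured step changes the group on an amide-type nitrogen rather than the chlorophenyl, and a 1.4-fold higher number from compound 1 to compound 2 (0.15 log units; within the scatter) is all it gave. Going by the values given here, no measured step moves the chlorine, so no step beyond the scatter is expected in this assay for this change. The expected change is a 1.1-fold higher number from compound 1 to compound 4 (0.03 log units; within the scatter) and lies within the scatter. Compound 4 is estimated at 250 nm/s and is expected to fall between 130 nm/s and 450 nm/s.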

Compound 4, apparent permeability: 100 nm/s
Estimate against measurement, compound 4: 2.5-fold (0.40 log units) above; measured number below the stated range.
By their numbers in this assay, from the lowest: compound 4; then compounds 1, 2 and 3 (each within the scatter of the next).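

Moving the chlorine gives the first step here that lies beyond the scatter: in this assay the change to 2-chlorophenyl from 3-chlorophenyl gives a 2.4-fold lower number from compound 1 to compound 4 (0.37 log units; beyond the scatter) with no atom gained or lost. So at this place on the saturated chain carbon, the way the same atoms are joined can shift this read-out. Nothing measured here accounts for the drop. From the compounds shown here alone, whether fluorine or a methyl group in place of the chlorine would give a similar number stays open. So does whether the same chlorine move would have a similar effect with the amide-nitrogen group of compound 2.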